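The compounds below may be only part of what the source reports. "The series", "measured", "known", "first", "only" and "open" are said of these compounds alone.

Compound 1 `COc1ccc(-c2cc(=O)c3c(OC)cc(OC)cc3[nH]2)cc1`: in a functional assay on KOPN-8 cells (Homo sapiens) for antiproliferative activity, with a stated time of 72 h (on this read-out higher numbers stand for an effect only at larger amounts of compound and lower numbers for an effect already at smaller amounts), compound 1 reaches only a limit, > 31100 nM.
Compound 2 `COc1ccc(-c2cc(=O)c3c(OC)cc(OC)cc3n2C)cc1`: in this assay compound 2 gives 30000 nM.
Compound 3 `COc1ccc(-c2cc(=O)c3c(OC)cc(OC)cc3n2S(=O)(=O)c2cc(Cl)cc(Cl)c2O)cc1`: in this assay compound 3 reaches only a limit, > 37900 nM.

Compound 1 thus stands at the upper edge of what this assay can report, as one of two such limits among the three values, the limit of > 31100 nM in this assay, at which 1 of the 3 values shown sits, and (the limit of > 37900 nM in this assay, at which 1 of the 3 values shown sits). Within the data shown here, only compound 2 returns a number, and the one measured step from compound 1, an at least 1.0-fold lower number from compound 1 to compound 2 (0.01 log units; that floor lies within the scatter), stays within the scatter. Compound 4 `COc1ccc(-c2cc(=O)c3c(OC)cc(OC)cc3n2S(=O)(=O)c2ccc(Br)cc2)cc1` differs from compound 1 by (4-bromophenyl)sulfonyl in place of hydrogen on an aromatic nitrogen. Among the measured compounds shown here, no measured step covers exactly this change; the nearest point of comparison is compound 3, which also carries a sulfonyl group on that nitrogen and reaches only a limit. Since neither compound 1 nor compound 3 gives a number, no step beyond the scatter is expected from this change, and compound 4 is estimated to sit at 35000 nM (range 15000 nM to 80000 nM), a step that the limit leaves unreadable from compound 1 to compound 4 that is expected to be indistinguishable from none, most likely reported only as a limit.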

Compound 4, half-maximal effective concentration: > 86200 nM
Compound 4: only a limit was reported; the forecaster's own chance of this, stated with the estimate: 70%; at least 2.4-fold (0.39 log units) between middle value and limit.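

In this assay compound 4 reaches only a limit, so a second sulfonyl group on the aromatic nitrogen again returns no number: the limit of > 86200 nM in this assay, at which 1 of the 4 values shown sits. Among these compounds, putting (4-bromophenyl)sulfonyl in place of methyl on that nitrogen gives the first step at this position that can be read and that lies beyond the scatter, an at least 2.8-fold higher number from compound 2 to compound 4 (0.45 log units; beyond the scatter). The steps to compound 4 from compound 1 and from compound 3 cannot be read, with limits at both ends, so neither the change from hydrogen nor the change of the group on the sulfonyl sulfur can be sized.

Open, as far as these compounds go, is whether any group on this nitrogen can bring the number down to a clearly lower level. A longer chain ending in an amine or a carboxylic acid there could test that.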